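A few compounds are considered here, and "the series" means these few. Any claim that something is new, unique, unknown or untested is made for them only; others in the source may bear on it.

Measured compounds:
compound 1, `N#Cc1ccc2ccc(C(=O)c3ccc(F)c(O)c3)nc2c1`: "not active" (no number reported)
compound 2, `Nc1ccc2ccc(C(=O)c3ccc(F)c(O)c3)nc2c1`: 21%
compound 3, `O=C(c1ccc(F)c(O)c1)c1ccc2ccccc2n1`: 6%

In an assay for inhibition of 17-beta-hydroxysteroid dehydrogenase type 1 (Homo sapiens), read by HPLC, with a stated time of 10 min, tested at 1 uM (a higher number here means more inhibition at the concentration tested (going by the name of the read-out), a lower number less inhibition), compound 3 gives 6%, the lowest of the two numbers reported. Compound 2 gives 21%, and compound 1 is reported as "not active" (no number reported) without a number. Compound 4, `O=C(O)CNc1ccc2ccc(C(=O)c3ccc(F)c(O)c3)nc2c1`, differs from compound 3 in one place: (carboxymethyl)amino in place of hydrogen on an aromatic carbon. Within the data shown here, the one measured step that bears on this change is a number 15 percentage points lower from compound 2 to compound 3 (beyond the scatter), which runs the opposite way, a group on an aromatic carbon being removed. Compound 1 shows that a different group on an aromatic carbon gave no number at all. A modest rise is therefore expected, of about a number 12 percentage points higher from compound 3 to compound 4 (beyond the scatter). Compound 4 is expected to give about 18% in this assay, with a range of 2% to 38%.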

Compound 4, a percentage reported as inhibition, at one concentration (the size of the read-out at that concentration, not a potency) in the 17-beta-hydroxysteroid dehydrogenase type 1 assay: 3%
The estimate for compound 4 lay 15 percentage points above the measured number, and the stated range covers the measured number.
By their numbers in the 17-beta-hydroxysteroid dehydrogenase type 1 assay, from the lowest: compounds 4 and 3 (each within the scatter of the next); then compound 2.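

In the 17-beta-hydroxysteroid dehydrogenase type 1 assay, (carboxymethyl)amino on this aromatic carbon gives a number 3 percentage points lower from compound 3 to compound 4 (within the scatter), so the group leaves compound 4 indistinguishable from the unsubstituted compound 3. Also in the 17-beta-hydroxysteroid dehydrogenase type 1 assay, carboxymethyl on the amino nitrogen gives a number 18 percentage points lower from compound 2 to compound 4 (beyond the scatter), so the inhibition seen with the plain amino group of compound 2 does not persist after this change. In a physicochemical assay for solubility, in phosphate buffer, with a stated time of 24 h, at pH 7.4, tested at 200 uM (on this read-out higher numbers stand for higher solubility and lower numbers for lower solubility), compound 3 gives > 200000 nM, which is a limit of the assay and not a number. In the physicochemical assay compound 4 gives > 200000 nM, which is likewise a limit of the assay and not a number. In the physicochemical assay the step between compound 3 and compound 4 cannot be read: the limit of > 200000 nM in the physicochemical assay, at which 2 of the 2 values shown sit.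

As far as these compounds go, what stays open is whether a methylamino group, a longer chain ending in a carboxylic acid, or the methyl ester of compound 4 would keep the inhibition of compound 2.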